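Swapping a Short Chain for a Trimethoxyphenyl Group

This account rests on a few compounds, and the source may have more. Where it says the series, first, only, none or still open, it means among the compounds named here.

Three compounds share one core and differ only in the group on a saturated chain carbon bound to an amide-type nitrogen. In an ADME assay on C8166 cells (Homo sapiens) for cytotoxicity, read by MTT assay, with a stated time of 3 days (a higher number here means that more compound is tolerated, a lower number that less compound is tolerated), compound 1 `COc1ccc(CNC(=O)c2nc(C(C)(C)NC(=O)OCc3ccccc3)nc(O)c2O)cc1` gives 164000 nM, compound 2 `CC(C)(NC(=O)OCc1ccccc1)c1nc(O)c(O)c(C(=O)NCc2ccc(C(F)(F)F)cc2)n1` gives 58100 nM, and compound 3 `COCCCNC(=O)c1nc(C(C)(C)NC(=O)OCc2ccccc2)nc(O)c1O` gives 259000 nM. Compound 3 gives the highest of the three numbers, but compound 1 lies within the scatter of it, and only compound 2 is clearly lower. Compound 4 `COc1cc(CNC(=O)c2nc(C(C)(C)NC(=O)OCc3ccccc3)nc(O)c2O)cc(OC)c1OC` carries 3,4,5-trimethoxyphenyl in place of 2-methoxyethyl on a saturated chain carbon bound to an amide-type nitrogen. Among the measured compounds shown here, the steps that bear on this are a 1.6-fold higher number from compound 1 to compound 3 (0.20 log units; within the scatter) and a 4.5-fold higher number from compound 2 to compound 3 (0.65 log units; beyond the scatter): replacing an aromatic group with the short chain raised the number slightly or modestly, so returning to an aromatic group is expected to lower it somewhat. Compound 4 is therefore estimated at 120000 nM in this assay, within 50000 nM to 280000 nM. The expected step is a 2.2-fold lower number from compound 3 to compound 4 (0.33 log units; beyond the scatter).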

Compound 4, half-maximal cytotoxic concentration: 110000 nM
The estimate for compound 4 lay 1.1-fold (0.04 log units) above the measured number; measured number inside the range.
By their numbers in this assay, from the lowest: compounds 2, 4, 1 and 3 (each within the scatter of the next, the first and the last beyond it).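

In this assay, 3,4,5-trimethoxyphenyl in place of 2-methoxyethyl gives a 2.4-fold lower number from compound 3 to compound 4 (0.37 log units; beyond the scatter) and so confirms that aromatic groups can sit clearly apart from the short chain at this position. The comparisons among aromatic groups give a 1.5-fold lower number from compound 1 to compound 4 (0.17 log units; within the scatter) and a 1.9-fold higher number from compound 2 to compound 4 (0.28 log units; within the scatter) and both stay within the scatter. The trimethoxyphenyl group therefore cannot be separated from either 4-methoxyphenyl or 4-(trifluoromethyl)phenyl, although those two differ from each other.

Nothing measured here explains these differences. On these data alone, whether a longer chain, or a chain ending in an amine or a carboxylic acid, would match 2-methoxyethyl remains open.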